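Swapping a methoxyphenyl for a pyridyl on the triazole

A few compounds are considered here, and "the series" means these few. Any claim that something is new, unique, unknown or untested is made for them only; others in the source may bear on it.

Compound 1 `C=C1C[C@]23C[C@@]1(O)CC[C@H]2c1ccc(OS(=O)(=O)c2ccc(C)cc2)c(C)c1[C@@H]3Cn1cc(-c2ccc(OC)cc2)nn1` carries a 4-methoxyphenyl group on its triazole ring and a (4-methylphenyl)sulfonyl group on the phenolic oxygen of the shared core. In a functional assay on MCF7 cells (Homo sapiens) for cytotoxicity, read by MTT assay, with a stated time of 4 days (a higher number here means a weaker inhibitor, a lower number a stronger inhibitor), compound 1 gives only a limit, > 20000 nM, so its true potency is not pinned down. Compound 3 `C=C1C[C@]23C[C@@]1(O)CC[C@H]2c1ccc(O)c(C)c1[C@@H]3Cn1cc(-c2ccc(OC)cc2)nn1` likewise returns only a limit, > 20000 nM. Compound 2 `C=C1C[C@]23C[C@@]1(O)CC[C@H]2c1cc(Br)c(O)c(C)c1[C@@H]3Cn1cc(-c2ccc(F)cc2)nn1` gives 19200 nM in this assay. Among the measured compounds shown here, the single measured step, a step that the two limits leave unreadable from compound 1 to compound 3, cannot be sized because the limit of > 20000 nM in this assay, at which 2 of the 3 values shown sit, caps both of its ends, so no measured step bears on the change that follows.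

Compound 4 `C=C1C[C@]23C[C@@]1(O)CC[C@H]2c1ccc(OS(=O)(=O)c2ccc(C)cc2)c(C)c1[C@@H]3Cn1cc(-c2ccccn2)nn1` differs from compound 1 by pyridin-2-yl in place of 4-methoxyphenyl on an aromatic carbon. Nothing measured here touches that swap, and all three measured values sit at or very close to the limit. In this assay compound 4 is therefore expected to give roughly 20000 nM, somewhere between 8000 nM and 50000 nM, most likely reported as a limit again. The expected step of a number no higher from compound 1 to compound 4 (the limit leaves the size open) is accordingly estimated as no change beyond the scatter.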

Compound 4, half-maximal inhibitory concentration: > 20000 nM
Compound 4 gave a limit, no number; the forecaster's own chance of this, stated with the estimate: 70%; the middle value lies on the limit itself.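

No step can be read from compound 1 to compound 4, because both give only a limit in this assay: the limit of > 20000 nM in this assay, at which 3 of the 4 values shown sit.

The compounds shown leave open whether pyridin-2-yl in place of 4-methoxyphenyl changes the potency of this series at all.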